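Compound 3: from the 4-methylphenyl to a silicon group

A few compounds are considered here, and "the series" means these few. Any claim that something is new, unique, unknown or untested is made for them only; others in the source may bear on it.

Compound 1 `O=C1O[C@H]([C@@H](O)Cn2cc(-c3ccc(Br)cc3)nn2)C(OCc2ccccc2)=C1OCc1ccccc1` gives 5100 nM in an ADME assay on HFF cells (Homo sapiens) for cytotoxicity, read by MTT assay, with a stated time of 72 h (on this read-out higher numbers stand for weaker inhibition and lower numbers for stronger inhibition), as a number
Compound 2 `Cc1ccc(-c2cn(C[C@H](O)[C@H]3OC(=O)C(OCc4ccccc4)=C3OCc3ccccc3)nn2)cc1` gives > 100000 nM as a limit of the assay
Compound 3 `C[Si](C)(C)c1cn(C[C@H](O)[C@H]2OC(=O)C(OCc3ccccc3)=C2OCc2ccccc2)nn1` is not yet measured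

Compound 2 has no exact number and stands at the limit of > 100000 nM in this assay, at which 1 of the 2 values shown sits, in this account. The change to compound 3 is a group of 4 heavy atoms (3 carbon, 1 silicon; no ring) in place of a group of 7 heavy atoms (7 carbon; one six-membered aromatic ring of carbon only), on an aromatic carbon with the new group on the same carbon. Within the data shown here, one measured step bears on this, namely an at least 19-fold higher number from compound 1 to compound 2 (1.29 log units; beyond the scatter) with methyl in place of bromo on an aromatic carbon. That step is large and beyond the scatter. It alters the very group that leaves here but does not remove it, so it is only a loose guide. A step from a limit can be read only toward lower numbers. Expected in this assay is an at least 2.0-fold lower number from compound 2 to compound 3 (0.30 log units; that floor lies within the scatter) as a moderate move, smaller than the measured one. For compound 3 the estimate is 50000 nM with a range from 10000 nM to 100000 nM as expected here, and the assay may again report only a limit.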

Compound 3, half-maximal inhibitory concentration: 20000 nM
The estimate for compound 3 lay 2.5-fold (0.40 log units) above the measured number, within the range that was stated.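

In this assay, the aromatic carbon of the five-membered aromatic ring with 3 nitrogen does not need a six-membered aromatic ring to give an exact number: the silicon group without a ring, in place of 4-methylphenyl, gives an at least 5.0-fold lower number from compound 2 to compound 3 (0.69 log units; beyond the scatter). Measured against the 4-bromophenyl group of compound 1, the same silicon group still reads higher, with a 3.9-fold higher number from compound 1 to compound 3 (0.59 log units; beyond the scatter), so the order here does not simply follow the presence of an aromatic ring at this carbon. Compound 2 has only a limit, so the first step gives a floor and not a size: the limit of > 100000 nM in this assay, at which 1 of the 3 values shown sits.

The compounds shown leave open how a ring-free tert-butyl group at this carbon would compare with the silicon group. They also leave open how an amine or a longer alkyl chain would read there.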